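Moving the bromine around the phenoxy ring of compound 2

The compounds below may be only part of what the source reports. "The series", "measured", "known", "first", "only" and "open" are said of these compounds alone.

Compound 2 `Cc1nn(C)c(Oc2cccc(Br)c2)c1/C=N\CCCCCCOc1cc2oc(=O)cc(C)c2cc1Cl` carries a 3-bromophenyl on an oxygen on an aromatic ring. Among the measured compounds shown here, in a functional assay on SMMC-7721 cells (Homo sapiens) for antiproliferative activity, read by MTT assay, with a stated time of 72 h (on this read-out lower numbers stand for stronger inhibition and higher numbers for weaker inhibition), compound 2 gives 5080 nM, the lower of the two numbers measured so far. Its neighbour compound 1 `Cc1nn(C)c(Oc2ccc(F)cc2)c1/C=N\CCCCCCOc1cc2oc(=O)cc(C)c2cc1Cl` carries a 4-fluorophenyl at the same place, and in this assay compound 1 gives 13500 nM. For the measured compounds named here, the only measured step, a 2.7-fold lower number from compound 1 to compound 2 (0.42 log units; beyond the scatter), changes both the halogen and its position at once.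

Compound 3 `Cc1nn(C)c(Oc2ccc(Br)cc2)c1/C=N\CCCCCCOc1cc2oc(=O)cc(C)c2cc1Cl` is not yet measured. The change from compound 2 to compound 3 is 4-bromophenyl in place of 3-bromophenyl on an oxygen on an aromatic ring, so the halogen stays and only its position shifts. The measured step bears on this only in part, since it does not separate position from halogen type. A step of modest size or none beyond the scatter is therefore expected, most likely towards a somewhat higher number, as a 1.5-fold higher number from compound 2 to compound 3 (0.17 log units; within the scatter). Compound 3 is expected to give about 7500 nM, between 2500 nM and 22000 nM.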

Compound 3, half-maximal inhibitory concentration: 3090 nM
Compound 3: middle estimate off by 2.4-fold (0.39 log units), on the high side, within the range that was stated.
By their numbers in this assay, from the lowest: compounds 3 and 2 (each within the scatter of the next); then compound 1.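

Compound 3 separates the two changes that the earlier step made at once. With the halogen kept, 4-bromophenyl in place of 3-bromophenyl gives a 1.6-fold lower number from compound 2 to compound 3 (0.22 log units; within the scatter) in this assay, so where the bromine sits on this ring makes no difference that can be told from the scatter, while with the placement kept, bromo in place of fluoro gives a 4.4-fold lower number from compound 1 to compound 3 (0.64 log units; beyond the scatter), a modest step that the scatter does not cover. No measurement here explains this difference between the two halogens.

Going by these compounds, only bromo and fluoro are compared here, so it remains open how a chloro, methoxy or trifluoromethyl group, or a plain phenyl without any halogen, would read at this place. On these data alone, whether the same holds with a shorter or longer chain in the rest of the molecule also remains open.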